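Replacing 1,3-thiazol-2-yl with 5-carboxythiophen-2-yl on the shared core

The source may report more compounds than this note shows. Statements on the series, on what has been measured and on what is new or still open speak of the compounds shown alone.

In a physicochemical assay for solubility, in phosphate buffer, with a stated time of 18 h (on this read-out higher numbers stand for higher solubility and lower numbers for lower solubility), compound 1 `N#Cc1c(N)nc2nc(C3CC3)ncc2c1N` gives 23000 nM and compound 2 `N#Cc1c(N)nc2nc(C3CCC3)ncc2c1N` gives 217000 nM. Within the data shown here, that pair supplies the only measured step, a 9.4-fold higher number from compound 1 to compound 2 (0.97 log units; beyond the scatter), with cyclobutyl in place of cyclopropyl on an aromatic carbon. It involves neither group exchanged here, so it shows only how far this read-out can move after one small change.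

Compound 3 `CC(C)(C)c1nc(-c2nccs2)c2c(N)c(C#N)c(N)nc2n1` reads < 1500 nM, which is a limit of the assay and not a number.

Compound 4 `CC(C)(C)c1nc(-c2ccc(C(=O)O)s2)c2c(N)c(C#N)c(N)nc2n1` carries 5-carboxythiophen-2-yl in place of 1,3-thiazol-2-yl on an aromatic carbon. Among the measured compounds shown here, no measured step covers this place, so the expectation is tentative. A higher number is expected, the estimated step being an at least 26-fold higher number from compound 3 to compound 4 (1.42 log units; beyond the scatter). For compound 4 the estimated value is 40000 nM, with an expected range from 5000 nM to 250000 nM.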

Compound 4, solubility: > 1000000 nM
Compound 4 gave a limit, no number (the forecaster's own chance of this, stated with the estimate: 15%); middle value at least 25-fold (1.39 log units) from the limit.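

At this position on the shared core, 5-carboxythiophen-2-yl in place of 1,3-thiazol-2-yl gives an at least 660-fold higher number from compound 3 to compound 4 (2.82 log units; beyond the scatter), the first step read here. Compound 3 stands at a limit, not a number: the limit of < 1500 nM in this assay, at which 1 of the 4 values shown sits.

Compound 4 also stands at a limit, not a number: the limit of > 1000000 nM in this assay, at which 1 of the 4 values shown sits.

As far as these compounds go, the full size of the step therefore stays open. Also open, from the compounds shown here alone, is whether a methyl ester or a primary amide in place of the carboxylic acid would move this read-out as far, and how much of the step belongs to the exchanged ring itself.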